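Moving the Trifluoromethyl Group on the Aryl Ring

The source may hold more compounds than are shown below. What is called first, only, known or untested is meant among the compounds shown, and "the series" means these compounds.

Measured compounds:
compound 1 `CCCc1nc(-c2ccccc2)c(CNCCN2CCN(c3cccc(C)c3)CC2)o1` — 43.1%
compound 2 `CCCc1nc(-c2ccccc2)c(CNCCCN2CCN(c3cccc(C(F)(F)F)c3)CC2)o1` — 51.6%
compound 3 `CCCc1nc(-c2ccccc2)c(CNCCN2CCN(c3ccc(F)cc3)CC2)o1` — 54.1%

All three share one core and differ only in the aryl group carried by the piperazine-type ring nitrogen, along with the length of the chain leading to it. In an assay on HEK293 cells for inhibition of Voltage-dependent T-type calcium channel subunit alpha-1G (Homo sapiens), read by fluorescence, tested at 10 uM (on this read-out lower numbers stand for less inhibition and higher numbers for more inhibition at the one concentration tested (going by the name of the read-out)), compound 2 gives 51.6%. Its number lies between those of compound 1 and compound 3, but both gaps are within the usual scatter, so the three cannot be ranked with confidence.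

Compound 4 `CCCc1nc(-c2ccccc2)c(CNCCCN2CCN(c3ccccc3C(F)(F)F)CC2)o1` is made from compound 2 by a change of attachment point: 2-(trifluoromethyl)phenyl in place of 3-(trifluoromethyl)phenyl on an amine nitrogen in a ring.

Going by the values given here, only one measured step touches the same place. a number 11 percentage points higher from compound 1 to compound 3 (beyond the scatter) swaps one aryl group for another on that ring nitrogen and gave a modest shift. Among the compounds with values here, no measured step moves a trifluoromethyl group from one position of the phenyl ring to another, so there is no direct guide. Given that the one aryl swap was modest and the three measured numbers sit close together, the expectation for this assay is a step of a number 3.6 percentage points lower from compound 2 to compound 4 (within the scatter), that is, nothing clearly beyond the scatter. Compound 4 is therefore estimated at 48%, within a range from 30% to 66%.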

Compound 4, a percentage reported as inhibition, at one concentration (the size of the read-out at that concentration, not a potency): 45%
For compound 4 the middle estimate is 3 percentage points above the measured one, and the stated range covers the measured number.
By their numbers in this assay, from the lowest: compounds 1, 4, 2 and 3 (each within the scatter of the next, the first and the last beyond it).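

Moving the trifluoromethyl group, with 2-(trifluoromethyl)phenyl in place of 3-(trifluoromethyl)phenyl on the ring nitrogen, gives in this assay a number 6.6 percentage points lower from compound 2 to compound 4 (within the scatter), so this read-out does not separate the two attachment points. The earlier step between compound 1 and compound 3 exchanged one aryl group for a different one, whereas the groups compared here have the same atoms, joined differently, which isolates the place of the trifluoromethyl group on the phenyl ring for this one pair. Nothing available bears on what lies behind this result.

As far as these compounds go, how a nitrile or a methoxy group would read in place of trifluoromethyl on this phenyl ring remains open, as does the effect of a longer chain leading to the ring nitrogen. The read-out also comes from a single concentration and is not a potency, so the compounds shown cannot settle whether compound 2 and compound 4 would differ across a range of concentrations.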